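A few compounds are considered here, and "the series" means these few. Any claim that something is new, unique, unknown or untested is made for them only; others in the source may bear on it.

Measured so far in a functional assay on HepG2 cells (Homo sapiens) for antiproliferative activity, read by sulforhodamine B assay, with a stated time of 48 h; on this read-out lower numbers stand for stronger inhibition and higher numbers for weaker inhibition:
Compound 1 `COc1ccc(C2C=C(c3cc(OC)c(OC)c(OC)c3)NC(=S)N2)cc1` gives 90 nM
Compound 2 `COc1cccc(C2=CC(c3ccc(Cl)cc3)NC(=S)N2)c1` gives 54 nM
Compound 3 `COc1cccc(C(=O)C(O)C(Nc2ccc(F)c(Cl)c2)c2ccc(Br)cc2)c1` gives 37.2 nM

Compound 2 at 54 nM lies within the usual scatter of both other compounds, so no order can be read between it and compound 3, or between it and compound 1.

Compound 4 `COc1cccc(C2=CC(c3ccc(Br)cc3)NC(=S)N2)c1` has not yet been measured. It is compound 2 with a single change, (bromo in place of chloro on an aromatic carbon), in words bromo in place of chloro on an aromatic carbon, para to a large group: 4-chlorophenyl becomes 4-bromophenyl. Among the compounds with values here, no pair of measured compounds shows this swap, so the data give no direct size for it. Compound 3 at 37.2 nM also carries a 4-bromophenyl, but the rest of its structure differs from that of compound 2, so it offers no clean comparison.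

In this assay the expectation is therefore no step beyond the scatter, in either direction, and the estimate stays close to compound 2 at 54 nM as its starting point. The expected change is small, a 1.1-fold lower number from compound 2 to compound 4 (0.03 log units; within the scatter), and lies within the scatter. For compound 4 the estimated value is 50 nM, with an expected range from 22 nM to 110 nM in repeated measurements.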

Compound 4, half-maximal inhibitory concentration: 34 nM
The estimate for compound 4 lay 1.5-fold (0.17 log units) above the measured number; low and high end bracket the measured number.
By their numbers in this assay, from the lowest: compounds 4, 3, 2 and 1 (each within the scatter of the next, the first and the last beyond it).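

In this assay the change from 4-chlorophenyl to 4-bromophenyl now has a first direct size, a 1.6-fold lower number from compound 2 to compound 4 (0.20 log units; within the scatter), and this pair is the only one here that isolates it. The step stays within the usual scatter, so no order can be read between the two compounds, and at this aromatic carbon, para to a large group, chloro and bromo cannot be told apart on this read-out. Nothing available here bears on why the two compounds give the values they do.

From the compounds shown here alone, what happens at this position with a group of a different kind, such as a nitrile, a trifluoromethyl or a carboxylic acid, remains open, since one swap between two halogens says little about the wider range of groups the position might accept. Going by these compounds, it is also open whether the same swap would give a similar step on another core, such as that of compound 1 or compound 3, as neither of these forms a matched pair with a compound differing only by this change.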